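Selenium Naphthoquinone Esters: Disulfide to Hydroxyl in Cytotoxicity

The source may report more compounds than this note shows. Statements on the series, on what has been measured and on what is new or still open speak of the compounds shown alone.

The measured compounds and their values:
compound 1 `CC1=C([Se]CC(OC(=O)CC[Se]c2ccccc2)C(=O)NCCCCCC(=O)OCc2ccccc2)C(=O)c2ccccc2C1=O`: 4000 nM
compound 2 `CC1=C([Se]CC(OC(=O)[C@@H](CSSC(C)(C)C)NC(=O)OC(C)(C)C)C(=O)NC(C)(C)C)C(=O)c2ccccc2C1=O`: 2000 nM
compound 3 `CC1=C(SCCC(=O)OC(C[Se]C2=C(C)C(=O)c3ccccc3C2=O)C(=O)NC(C)(C)C)C(=O)c2ccccc2C1=O`: 1000 nM

In a functional assay on A-431 cells (Homo sapiens) for cytotoxicity, read by MTT assay, with a stated time of 24 h (a higher number here means a weaker inhibitor, a lower number a stronger inhibitor), compound 2 gives 2000 nM. It holds the second highest of the three numbers. Its nearest neighbour is compound 1 and the furthest is compound 3; both gaps lie within the scatter, so the three compounds cannot be ranked against one another on these numbers.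

Compound 4 `CC1=C([Se]CC(OC(=O)[C@@H](CO)NC(=O)OC(C)(C)C)C(=O)NC(C)(C)C)C(=O)c2ccccc2C1=O` has not yet been measured in this assay. It differs from compound 2 in one place: hydroxy in place of ((tert-butyl)sulfanyl)sulfanyl on a saturated chain carbon, two bonds along the chain from an amide-type nitrogen and a carbonyl carbon. Among the measured compounds shown here, no step between two measured compounds matches this change, so nothing in the set shows how swapping a ((tert-butyl)sulfanyl)sulfanyl for a hydroxy on that chain carbon acts on the read-out. The three measured values sit close together, which suggests the chain ester portion tolerates variation without moving the number much.

Compound 4 is therefore expected to stay near compound 2, with a step of a 1.5-fold higher number from compound 2 to compound 4 (0.18 log units; within the scatter) that is estimated to remain within the scatter. The estimate for compound 4 is 3000 nM, with a likely range from 1000 nM to 10000 nM.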

Compound 4, half-maximal inhibitory concentration: 2000 nM
Estimate against measurement, compound 4: 1.5-fold (0.18 log units) above; low and high end bracket the measured number.
By their numbers in this assay, from the lowest: compounds 3, 2, 4 and 1 (each within the scatter of the next, the first and the last beyond it).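

Among the compounds shown here, replacing the ((tert-butyl)sulfanyl)sulfanyl group with hydroxy on a saturated chain carbon, two bonds along the chain from an amide-type nitrogen and a carbonyl carbon, gives no change at the digits printed from compound 2 to compound 4 (within the scatter) in this assay and is the first comparison in the set that differs in one place only. At this position, then, a group of six heavy atoms, two of them sulfur, gives way to a single oxygen with no movement beyond the scatter. Nothing available explains why the number holds across this change.

Going by these compounds, how an amine, a carboxylic acid or a longer alkyl chain on this carbon would read remains open. Also open, on these data alone, is whether the same tolerance would hold if the tert-butyl amide were exchanged for another amide group.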